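The compounds below may be only part of what the source reports. "The series", "measured", "known", "first", "only" and "open" are said of these compounds alone.

Among the measured compounds shown here, in a functional assay on SH-SY5Y cells (Homo sapiens) for cytotoxicity, read by MTT assay, with stated times of 1 h and 24 h (on this read-out higher numbers stand for an effect only at larger amounts of compound and lower numbers for an effect already at smaller amounts), compound 2 `Cc1cc(O)cc2oc(=O)c(C(=O)CCN(C)C)cc12` gives 19700 nM, the only actual number so far. Compound 1 `O=C(CCN1CCCCC1)c1cc2ccc(O)cc2oc1=O`, which carries piperidin-1-yl, reads > 100000 nM, and this is a limit of the assay. Compound 3 `Cc1cc(O)cc2oc(=O)c(C(=O)CCN3CCCCC3)cc12` differs from compound 2 in one place: piperidin-1-yl in place of dimethylamino on a saturated chain carbon, two bonds along the chain from a carbonyl carbon. For the measured compounds named here, no measured step covers this change, so the expectation rests on compound 1 at > 100000 nM alone: a modest shift towards larger amounts in this assay. The expected step is a 1.8-fold higher number from compound 2 to compound 3 (0.25 log units; within the scatter). For compound 3 the estimate is 35000 nM, with an expected range of 12000 nM to 100000 nM.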

Compound 3, half-maximal effective concentration: 83700 nM
Compound 3: middle estimate off by 2.4-fold (0.38 log units), on the low side; the range from low to high includes it.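

In this assay, piperidin-1-yl in place of dimethylamino on a saturated chain carbon, two bonds along the chain from a carbonyl carbon, now has a measured size on the core of compound 2: a 4.2-fold higher number from compound 2 to compound 3 (0.63 log units; beyond the scatter). Methyl in place of hydrogen on an aromatic carbon gives only an at least 1.1-fold lower number from compound 1 to compound 3 (0.07 log units; that floor lies within the scatter), so no shift from that change can be claimed. Compound 1 stands at a limit: the limit of > 100000 nM in this assay, at which 1 of the 3 values shown sits.

Open, from the compounds shown here alone, is whether morpholin-4-yl or diethylamino at this place, or a longer chain, would extend the shift. Also open, going by these compounds, is how the aromatic methyl reads with dimethylamino on the chain.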